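Para-chloro on the benzyl: compound 3 from compound 1

The source may report more compounds than this note shows. Statements on the series, on what has been measured and on what is new or still open speak of the compounds shown alone.

Among the compounds with values here, compound 1 `CC(C)(COC(=O)[C@@H](N)c1ccccc1)COC1(c2ccc(Cl)cc2)c2ccccc2C(=O)N1Cc1ccccc1` gives 44000 nM in a functional assay on HCT-116 cells (Homo sapiens) for inhibition, read by fluorescence, with a stated time of 48 h (a lower number here means a stronger inhibitor of growth, a higher number a weaker inhibitor of growth), the lowest of the two numbers so far, while compound 2 `CC(C)(CO)COC1(c2ccc(Cl)cc2)c2ccccc2C(=O)N1Cc1ccccc1` gives 82000 nM; the step of a 1.9-fold higher number from compound 1 to compound 2 (0.27 log units; within the scatter) lies within the scatter, so the two are not separable. Compound 3 `CC(C)(COC(=O)[C@@H](N)c1ccccc1)COC1(c2ccc(Cl)cc2)c2ccccc2C(=O)N1Cc1ccc(Cl)cc1` differs from compound 1 by chloro in place of hydrogen on an aromatic carbon. Within the data shown here, no measured step touches this part of the core, so the only guide is that the one change seen in this assay left the number essentially unmoved. The expected step of no change at the digits printed from compound 1 to compound 3 (within the scatter) is therefore none beyond the scatter, and compound 3 is estimated at 44000 nM, between 15000 nM and 130000 nM.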

Compound 3, concentration for 50% growth inhibition: 38000 nM
Compound 3: the middle estimate sits 1.2-fold (0.06 log units) above what was measured, and the stated range covers the measured number.
By their numbers in this assay, from the lowest: compounds 3, 1 and 2 (each within the scatter of the next, the first and the last beyond it).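

In this assay, within the data shown here, benzyl to 4-chlorobenzyl gives a 1.2-fold lower number from compound 1 to compound 3 (0.06 log units; within the scatter) and so leaves the two compounds unseparated, the first reading on this part of the core. A single chloro on this aromatic carbon, para to a large group, therefore produces no step beyond the scatter. No available measurement offers an explanation for this result. Open, from the compounds shown here alone, is whether a methoxy group, an amine or a carboxylic acid at this place would move the number beyond the scatter. Also open, going by these compounds, is whether replacing the whole benzyl with a longer chain would do so.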